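A limit value and the step to compound 4

A few compounds are considered here, and "the series" means these few. Any claim that something is new, unique, unknown or untested is made for them only; others in the source may bear on it.

Compound 1 `COc1ccc(/C=C\c2cc(OC)c(OC)c(OC)c2)cc1OCc1ccc(C=O)cc1` carries a formyl group on the shared core. In an ADME assay on NCM460 cells (Homo sapiens) for cytotoxicity, read by CCK-8 assay, with a stated time of 48 h (a higher number here means a weaker inhibitor, a lower number a stronger inhibitor), compound 1 gives 41000 nM. Compound 2 `COc1ccc(/C=C\c2cc(OC)c(OC)c(OC)c2)cc1OCc1ccc(CN2CCCC[C@H]2C(=O)O)cc1` and compound 3 `COc1ccc(/C=C\c2cc(OC)c(OC)c(OC)c2)cc1OCc1ccc(CN2CCCCC2C(=O)O)cc1` carry (2-carboxypiperidin-1-yl)methyl in place of that formyl. Compound 2 gives > 50000 nM, which is a limit and not a number. Compound 3 gives > 50000 nM, also a limit and not a number, so it stands at the limit of > 50000 nM in this assay, at which 2 of the 3 values shown sit. The replacement of formyl gives an at least 1.2-fold higher number from compound 1 to compound 2 (0.08 log units; that floor lies within the scatter), and likewise an at least 1.2-fold higher number from compound 1 to compound 3 (0.08 log units; that floor lies within the scatter). There is also a step that the two limits leave unreadable from compound 2 to compound 3, so the fact that one of compounds 2 and 3 is drawn with a defined configuration and the other without, at the place where they differ adds no readable size.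

Compound 4 `COc1ccc(/C=C\c2cc(OC)c(OC)c(OC)c2)cc1OCc1ccc(CN[C@H](C(=O)O)[C@H](C)O)cc1` has not yet been measured. The change is (1-carboxy-2-hydroxypropyl)amino in place of 2-carboxypiperidin-1-yl on a saturated chain carbon bound to an aromatic carbon, with (1-carboxy-2-hydroxypropyl)amino taking the place of 2-carboxypiperidin-1-yl on a saturated chain carbon bound to an aromatic carbon. Among the compounds with values here, no measured step covers this exchange directly. No step beyond the scatter is expected in this assay, and no direction can be read, because compound 3 gives > 50000 nM. The expected step is a step that the limit leaves unreadable from compound 3 to compound 4. A report of only a limit is the likeliest outcome. For compound 4 the estimated value is 60000 nM, with an expected range from 30000 nM to 120000 nM.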

Compound 4, half-maximal inhibitory concentration: > 50000 nM
Compound 4: a limit, no number; the forecaster's own chance of this, stated with the estimate: 75%; the middle value does not contradict the limit.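

In this assay compound 4 gives > 50000 nM, which is a limit and not a number. The ((1-carboxy-2-hydroxypropyl)amino)methyl group, which has no ring, thus ends at the same limit as the ring-bearing (2-carboxypiperidin-1-yl)methyl group, so at this place on a saturated chain carbon bound to an aromatic carbon, the six-membered ring is not required to reach that limit: the limit of > 50000 nM in this assay, at which 3 of the 4 values shown sit. Of the steps reaching compound 4, only one can be read, an at least 1.2-fold higher number from compound 1 to compound 4 (0.08 log units; that floor lies within the scatter), and the two that start from the other limits cannot be read.

Going by these compounds, it stays open whether a plain piperidin-1-yl group, or a methyl ester in place of the carboxylic acid, would give a number rather than a limit in this assay. On these data alone, with the values shown, it also stays open how far any of the amino acid groups lies from the formyl group, since each comparison rests on a limit.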